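A few compounds are considered here, and "the series" means these few. Any claim that something is new, unique, unknown or untested is made for them only; others in the source may bear on it.

Measured so far:
Compound 1, `COc1ccc(F)cc1CNCCCNc1ccnc2cc(C3CCCCC3)ccc12`: 4200 nM
Compound 2, `COc1cccc(Oc2ccc3c(NCCCNCc4cc(F)ccc4OC)ccnc3c2)c1`: 14500 nM
Compound 3, `CCC(CC)c1ccc2c(NCCCNCc3cc(F)ccc3OC)ccnc2c1`: 4200 nM

Within the data shown here, in a physicochemical assay for solubility, with a stated time of 18 h, at pH 7.4 (a higher number here means a more soluble compound, a lower number a less soluble compound), compound 3 stands level with compound 1 and, with it, at the lowest of the three numbers; the only step beyond the scatter is a 3.5-fold lower number from compound 2 to compound 3 (0.54 log units; beyond the scatter). Compound 4, `COc1ccc(-c2ccc3c(NCCCNCc4cc(F)ccc4OC)ccnc3c2)cc1`, differs from compound 3 in one place: 4-methoxyphenyl in place of pentan-3-yl on an aromatic carbon. Among the measured compounds shown here, the steps that bear on this change are a 3.5-fold higher number from compound 1 to compound 2 (0.54 log units; beyond the scatter) and a 3.5-fold lower number from compound 2 to compound 3 (0.54 log units; beyond the scatter), both modest and both pointing to a higher number where an aromatic group with a methoxy replaces an aliphatic one. Compound 4 is therefore expected to sit somewhat higher than compound 3, with a step of a 1.9-fold higher number from compound 3 to compound 4 (0.28 log units; within the scatter). The estimate for compound 4 in this assay is 8000 nM, within 2500 nM to 25000 nM.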

Compound 4, solubility: 32000 nM
Compound 4: middle estimate off by 4.0-fold (0.60 log units), on the low side; measured number above the stated range.
By their numbers in this assay, from the lowest: compounds 1 and 3 (each within the scatter of the next); then compound 2; then compound 4.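

In this assay, 4-methoxyphenyl on this aromatic carbon gives the highest number of the four compounds, with a 7.6-fold higher number from compound 3 to compound 4 (0.88 log units; beyond the scatter) and a 7.6-fold higher number from compound 1 to compound 4 (0.88 log units; beyond the scatter), so the aliphatic groups are clearly surpassed. The two groups carrying a methoxy are also not equivalent here, with a 2.2-fold higher number from compound 2 to compound 4 (0.34 log units; beyond the scatter). Nothing measured here explains these rises. The compounds shown leave open whether the ring or the methoxy accounts for the step from pentan-3-yl. A plain phenyl, or a phenyl carrying a carboxylic acid or an amine, could help separate these contributions.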